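From 3-chlorophenyl to 4-cyanophenyl at an assay limit

The compounds below may be only part of what the source reports. "The series", "measured", "known", "first", "only" and "open" are said of these compounds alone.

In a physicochemical assay for solubility, using the shake flask method, measured as kinetic solubility, with a stated time of 2 h, at pH 7.4 (on this read-out higher numbers stand for higher solubility and lower numbers for lower solubility), compound 1 (`CN(Cc1ccc(F)cc1)c1cc(C(=O)Nc2ccccc2)ncn1`) returns only a limit (< 5000 nM). Compound 2 (`CN(Cc1cccc(Cl)c1)c1cc(C(=O)Nc2ccccc2)ncn1`) also returns only a limit (< 5000 nM), so its position rests on no exact number. Compound 3 (`CN(Cc1ccc(C#N)cc1)c1cc(C(=O)Nc2ccccc2)ncn1`) carries 4-cyanophenyl in place of 3-chlorophenyl on a saturated chain carbon bound to a nitrogen on an aromatic ring. Going by the values given here, only one measured step bears on this change, and it offers no size to carry over (a step that the two limits leave unreadable from compound 1 to compound 2). Because of the limit of < 5000 nM in this assay, at which 2 of the 2 values shown sit, no direction can be read from compound 1 or compound 2 either. The expected step is none beyond the scatter, with no direction favoured (a step that the limit leaves unreadable from compound 2 to compound 3). For compound 3 the estimated value is 3500 nM in this assay, with an expected range from 1000 nM to 10000 nM and a strong chance of another limit.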

Compound 3, solubility: < 5000 nM
Compound 3 ended at the assay's limit; the forecaster's own chance of this, stated with the estimate: 70%; the middle value does not contradict the limit.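

In this assay compound 3 returns < 5000 nM as a limit and not a number. Going by these compounds alone, no step among compound 1, compound 2 and compound 3 can be read, because all three rest on the same limit: the limit of < 5000 nM in this assay, at which 3 of the 3 values shown sit. The compounds shown leave open how the solubilities of these three compare.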